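This account rests on a few compounds, and the source may have more. Where it says the series, first, only, none or still open, it means among the compounds named here.

Three compounds of this series have numbers in a functional assay for antagonist activity at Adrenergic receptor alpha-1 (Rattus norvegicus); a lower number here means tighter binding, a higher number weaker binding. Compound 1 `Cc1ccccc1N1CCN(CCCOc2ccc3c(=O)cc(-c4ccccc4)oc3c2)CC1` gives 117 nM in this assay. Compound 2 `O=c1cc(-c2ccc(Cl)cc2)oc2cc(O)ccc12` gives 143 nM in this assay. Compound 3 `O=c1cc(-c2ccccc2)oc2cc(OCCBr)ccc12` gives 127 nM in this assay; that number is second highest of the three, and both compound 1 and compound 2 sit within the scatter of it, so no ordering among the three can be read from these values.

Compound 4 `O=c1cc(-c2ccc(Cl)cc2)oc2cc(OCCBr)ccc12` is the next member to be measured. It differs from compound 3 by chloro in place of hydrogen on an aromatic carbon. Within the data shown here, no measured pair shows this change on its own. Compound 2, which also carries the chloro group, gives 143 nM, within the scatter of compound 3, so no step beyond the scatter is expected from compound 3 to compound 4 in this assay. The expected step is a 1.1-fold lower number from compound 3 to compound 4 (0.02 log units; within the scatter), and compound 4 is estimated at 120 nM, between 50 nM and 300 nM.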

Compound 4, dissociation constant: 119 nM
Beside the measured number, compound 4's estimate is 1.0-fold (0.00 log units) above it; the range from low to high includes it.
By their numbers in this assay, from the lowest: compounds 1, 4, 3 and 2 (each within the scatter of the next).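

The change from phenyl to 4-chlorophenyl can now be read on its own in this assay: it gives a 1.1-fold lower number from compound 3 to compound 4 (0.03 log units; within the scatter) and so registers no difference for chloro on this aromatic carbon, para to a large group, with the 2-bromoethyl group present. With the chloro group present, 2-bromoethyl in place of hydrogen on the oxygen gives a 1.2-fold lower number from compound 2 to compound 4 (0.08 log units; within the scatter) and likewise registers no difference. No measurement here bears on why either change leaves the number within the scatter. Open, going by these compounds, is whether methoxy at the same carbon, or a carboxylic acid in place of the bromine, would move the number beyond the scatter.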